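Adding methanesulfonamido to the benzyl ring of the series

This account rests on a few compounds, and the source may have more. Where it says the series, first, only, none or still open, it means among the compounds named here.

Among the compounds with values here, compound 2 `O=C(O)CCc1ccc(NCc2ccccc2)cc1` gives 7940 nM in a functional assay for agonist activity at Free fatty acid receptor 1 (Homo sapiens) (on this read-out higher numbers stand for an effect only at larger amounts of compound and lower numbers for an effect already at smaller amounts), the higher of the two numbers so far; compound 1 `O=C(O)CCc1ccc(NCc2cccc(F)c2)cc1` gives 5010 nM, and the two lie within the scatter (a 1.6-fold higher number from compound 1 to compound 2 (0.20 log units; within the scatter)). Compound 3 `CS(=O)(=O)Nc1cccc(CNc2ccc(CCC(=O)O)cc2)c1` differs from compound 2 by methanesulfonamido in place of hydrogen on an aromatic carbon. Within the data shown here, the only measured step, the swap of fluoro for hydrogen, bears little on this larger change, so no direct precedent exists. Compound 3 is therefore expected near compound 2, with a mild shift toward a lower number, a 2.6-fold lower number from compound 2 to compound 3 (0.42 log units; beyond the scatter), estimated at 3000 nM (range 700 nM to 12000 nM).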

Compound 3, half-maximal effective concentration: < 31700 nM
Compound 3 gave a limit, no number; the forecaster's own chance of this, stated with the estimate: 10%; the middle value is on the limit's open side.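

In this assay, compound 3 gives only a limit, < 31700 nM, not a number, so its steps from compound 1 and compound 2 cannot be read. The compounds shown leave open how methanesulfonamido in place of hydrogen on an aromatic carbon shifts the number, or whether it does.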